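A few compounds are considered here, and "the series" means these few. Any claim that something is new, unique, unknown or untested is made for them only; others in the source may bear on it.

Compound 1 `O=S(=O)(Nc1ccc(-c2nc3ccccc3o2)cc1)c1cccc(Cl)c1` in an assay on isolated protein for inhibition of malate dehydrogenase, mitochondrial (Sus scrofa), with stated times of 45 min and 30 min (on this read-out lower numbers stand for stronger inhibition and higher numbers for weaker inhibition), gives only a limit, > 63000 nM.
Compound 2 `CS(=O)(=O)Nc1ccc(-c2nc3ccccc3o2)cc1` in this assay gives only a limit, > 63000 nM.
Compound 3 `COc1ccccc1S(=O)(=O)Nc1ccc(-c2nc3ccccc3o2)cc1` in this assay gives only a limit, > 63000 nM.

Compound 3 thus stands at the limit of > 63000 nM in this assay, at which 3 of the 3 values shown sit, together with the other two, and none of the three is set apart from another. The change to compound 4 `CCc1ccc(S(=O)(=O)Nc2ccc(-c3nc4ccccc4o3)cc2)cc1` is 4-ethylphenyl in place of 2-methoxyphenyl on a sulfonyl sulfur. The steps already measured on the same sulfonyl sulfur, a step that the two limits leave unreadable from compound 1 to compound 2, a step that the two limits leave unreadable from compound 1 to compound 3 and a step that the two limits leave unreadable from compound 2 to compound 3, give no readable size in this assay, so the size of the step to compound 4 cannot be read from them. Compound 4 is therefore expected to sit near the same limit, with a step that the limit leaves unreadable from compound 3 to compound 4 as the estimated step. The estimate for compound 4 in this assay is 100000 nM, with a range from 40000 nM to 300000 nM.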

Compound 4, half-maximal inhibitory concentration: > 63000 nM
Compound 4 ended at the assay's limit; the forecaster's own chance of this, stated with the estimate: 85%; the middle value is on the limit's open side.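

No step can be read among compound 1, compound 2, compound 3 and compound 4, since each value is only a limit: the limit of > 63000 nM in this assay, at which 4 of the 4 values shown sit.

Left open is whether any group on the sulfonyl sulfur gives a readable value in this assay.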